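The compounds below may be only part of what the source reports. "The series", "measured", "known", "first", "only" and "open" are said of these compounds alone.

Compound 1 `O=[N+]([O-])c1ccc(CN2CCC(n3cc(CC(OCc4cc(-c5ccc(Br)cc5)no4)c4ccc(Br)cc4)nn3)CC2)cc1` gives 5000 nM in a functional assay on MDA-MB-468 cells (Homo sapiens) for cytotoxicity, with a stated time of 48 h; on this read-out higher numbers stand for weaker inhibition and lower numbers for stronger inhibition. Compound 2 `COc1cccc(-c2cc(COC(Cc3cn(C4CCN(Cc5ccc([N+](=O)[O-])cc5)CC4)nn3)c3ccc(Br)cc3)on2)c1` gives > 25000 nM in this assay, and this is a limit of the assay rather than a number. Among the measured compounds shown here, the only measured step is an at least 5.0-fold higher number from compound 1 to compound 2 (0.69 log units; beyond the scatter), and its size is bounded by the limit of > 25000 nM in this assay, at which 1 of the 2 values shown sits. For the measured compounds named here, compound 3 `N#Cc1cccc(-c2cc(COC(Cc3cn(C4CCN(Cc5ccc([N+](=O)[O-])cc5)CC4)nn3)c3ccc(Br)cc3)on2)c1` differs from compound 2 by cyano in place of methoxy on an aromatic carbon; no measured step covers this change. Since compound 2 already sits at the limit, compound 3 is expected to remain near it, with a number no higher from compound 2 to compound 3 (the limit leaves the size open). Compound 3 is therefore estimated at 25000 nM, within 8000 nM to 80000 nM.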

Compound 3, half-maximal inhibitory concentration: > 25000 nM
Compound 3: no number, only a limit; the forecaster's own chance of this, stated with the estimate: 60%; the middle value lies on the limit itself.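

In this assay compound 3 gives > 25000 nM, which is a limit of the assay and not a number. The change from 4-bromophenyl to 3-cyanophenyl gives an at least 5.0-fold higher number from compound 1 to compound 3 (0.69 log units; beyond the scatter), so 3-cyanophenyl joins 3-methoxyphenyl as a second replacement with a step beyond the scatter. The step between compound 2 and compound 3 cannot be read, and methoxy and cyano stay unranked because both values are limits: the limit of > 25000 nM in this assay, at which 2 of the 3 values shown sit.

A 3-bromophenyl or 4-cyanophenyl analogue would separate the effect of the group from that of its place on the ring. On these data alone, the behaviour of an unsubstituted phenyl also remains open.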